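This account rests on a few compounds, and the source may have more. Where it says the series, first, only, none or still open, it means among the compounds named here.

Compound 1 `CCn1c(C(=O)NCCO)ccc1C(CC)(CC)c1ccc(OCS(=O)(=O)c2ccccc2)c(C)c1` gives 17700 nM
Compound 2 `CCn1c(C(=O)N[C@H](CO)CCO)ccc1C(CC)(CC)c1ccc(OCS(=O)(=O)c2ccccc2)c(C)c1` gives 12100 nM
Compound 3 `CCn1c(C(=O)NCC(=O)O)ccc1C(CC)(CC)c1ccc(OCS(=O)(=O)c2ccccc2)c(C)c1` gives 30100 nM

These three share one core and differ only in the group on the amide nitrogen. All were tested in a functional assay on PC-3 cells (Homo sapiens) for antiproliferative activity, read by MTT assay, with a stated time of 24 h; on this read-out higher numbers stand for weaker inhibition and lower numbers for stronger inhibition. Compound 3 stands at 30100 nM. It is clearly separated from only one of the other two: the data show a 2.5-fold higher number from compound 2 to compound 3 (0.40 log units; beyond the scatter), but also a 1.7-fold higher number from compound 1 to compound 3 (0.23 log units; within the scatter).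

Compound 4 `CCn1c(C(=O)N[C@@H](CC(=O)O)C(=O)O)ccc1C(CC)(CC)c1ccc(OCS(=O)(=O)c2ccccc2)c(C)c1` keeps the core of compound 3 and changes one thing: carboxymethyl in place of hydrogen on a saturated chain carbon bound to an amide-type nitrogen and a carbonyl carbon. Here carboxymethyl takes the place of hydrogen on a saturated chain carbon bound to an amide-type nitrogen and a carbonyl carbon, which turns carboxymethyl into 1,2-dicarboxyethyl.

Going by the values given here, no measured pair makes this exact change. The nearest case, a chain added on a similar carbon, is a 1.5-fold lower number from compound 1 to compound 2 (0.17 log units; within the scatter). The swap of hydroxymethyl for carboxy is a 1.7-fold higher number from compound 1 to compound 3 (0.23 log units; within the scatter). The largest step among these compounds, a 2.5-fold higher number from compound 2 to compound 3 (0.40 log units; beyond the scatter), is still modest. Side-chain changes have therefore moved the numbers little so far.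

The expected result is a 1.1-fold higher number from compound 3 to compound 4 (0.04 log units; within the scatter), which means no step beyond the scatter is expected in this assay. The estimate for compound 4 is 33000 nM, with an expected range from 16000 nM to 65000 nM.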

Compound 4, half-maximal inhibitory concentration: > 50000 nM
Compound 4 was reported as a limit; the forecaster's own chance of this, stated with the estimate: 15%; middle value at least 1.5-fold (0.18 log units) away from the limit.
By their numbers in this assay, from the lowest: compounds 2, 1 and 3 (each within the scatter of the next, the first and the last beyond it). At a limit, above all of these: compound 4.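

In this assay compound 4 is reported only as a limit of the assay, not as a number: the limit of > 50000 nM in this assay, at which 1 of the 4 values shown sits.

Going by these compounds alone, changing the group on the amide-type nitrogen to 1,2-dicarboxyethyl gives an at least 4.1-fold higher number from compound 2 to compound 4 (0.61 log units; beyond the scatter) and an at least 2.8-fold higher number from compound 1 to compound 4 (0.45 log units; beyond the scatter) and so adds two steps beyond the scatter, where the earlier compounds offered only one. Adding carboxymethyl on the saturated chain carbon bound to an amide-type nitrogen and a carbonyl carbon gives an at least 1.6-fold higher number from compound 3 to compound 4 (0.22 log units; that floor lies within the scatter) and that floor lies within the scatter, so this single change is not yet shown to separate compound 4 from compound 3, although the true step could be larger.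

On these data alone, the size of that step stays open, since the limit sets only its smallest possible value. Also open is how this position would respond to a group of another kind, such as an amine or a longer chain ending in a carboxylic acid, since every group shown here carries only hydroxyl or carboxy ends.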